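Anilino-to-dialkylamino switch on the shared quinone core

The compounds below may be only part of what the source reports. "The series", "measured", "known", "first", "only" and "open" are said of these compounds alone.

Measured so far in a functional assay on ECa-109 cells for inhibition, with ECa-109 cell line (Homo sapiens) as the target, read by sulforhodamine B assay; on this read-out higher numbers stand for weaker inhibition and lower numbers for stronger inhibition:
- compound 1 `Cc1ccc(NC2=CC(=O)c3nc4n(c3C2=O)[C@H]2OC[C@@H](O)[C@H]2OC4)cc1`: 3480 nM
- compound 2 `O=C1C(Nc2cccc(Cl)c2)=CC(=O)c2c1nc1n2[C@H]2OC[C@@H](O)[C@H]2OC1`: 3080 nM
- compound 3 `O=C1C(Nc2ccccc2F)=CC(=O)c2c1nc1n2[C@H]2OC[C@@H](O)[C@H]2OC1`: 2660 nM

Compound 1 gives the highest of the three numbers in this assay, yet it sits within the scatter of both compound 2 and compound 3, so no order among the three can be drawn. Going by the values given here, the one single-point step among them, a 1.2-fold lower number from compound 2 to compound 3 (0.06 log units; within the scatter), swaps one aryl group for another and stays flat.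

Compound 4 `CCCN(CCC)C1=CC(=O)c2nc3n(c2C1=O)[C@H]1OC[C@@H](O)[C@H]1OC3` departs from compound 1 by dipropylamino in place of (4-methylphenyl)amino on a double-bonded ring carbon. Among the compounds with values here, no measured step bears directly on this change: the aryl-to-aryl swap from compound 2 to compound 3 only shows that the core tolerates variation at this amine without a shift beyond the scatter. The loss of the aromatic ring and of the hydrogen-bond donor in compound 4 is uncharted here, so the expectation rests on the flat picture of the three arylamines and is given wide bounds.

Compound 4 is therefore expected near the measured cluster, at 4000 nM (range 1500 nM to 12000 nM), which would mean an estimated step of a 1.1-fold higher number from compound 1 to compound 4 (0.06 log units; within the scatter), most likely not beyond the scatter.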

Compound 4, half-maximal inhibitory concentration: > 16000 nM
Compound 4 gave a limit, no number (the forecaster's own chance of this, stated with the estimate: 10%); middle value at least 4.0-fold (0.60 log units) from the limit.
By their numbers in this assay, from the lowest: compounds 3, 2 and 1 (each within the scatter of the next). At a limit, above all of these: compound 4.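

The flat picture of compounds 1, 2 and 3 holds only among arylamino groups, since this position on the double-bonded ring carbon does respond to the kind of amine it carries: in this assay, the switch to dipropylamino gives an at least 4.5-fold higher number from compound 1 to compound 4 (0.66 log units; beyond the scatter). Compound 4 has a limit rather than a number, so the true size of this step is not fixed: the limit of > 16000 nM in this assay, at which 1 of the 4 values shown sits. The change removes the six-membered aromatic ring and the hydrogen-bond donor together and brings in two propyl chains, so this single step cannot assign the shift to any one of these features.

Open, on these data alone, is whether propylamino, which keeps a hydrogen-bond donor without an aromatic ring, would stay with the arylamines. N-methylanilino, which keeps the aromatic ring without that donor, would test the other half of the change.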